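The compounds below may be only part of what the source reports. "The series", "measured", "known", "first", "only" and "open" are said of these compounds alone.

In an in vitro ADME assay on microsomes from liver (Homo sapiens) for metabolic stability, read by HPLC (a higher number here means faster removal of the compound, a lower number slower removal), compound 1 `CC1(C)C[C@@H](CN([C@H](CCC(F)(F)F)C(N)=O)S(=O)(=O)c2ccc(Cl)cc2)O1` gives 16.5 mL/min/kg, while compound 2 `NC(=O)[C@@H](CCC(F)(F)F)N(C[C@@H]1COCCO1)S(=O)(=O)c1ccc(Cl)cc1` gives 117 mL/min/kg, the higher of the two numbers and so the faster removal. Compound 3 `NC(=O)[C@@H](CCC(F)(F)F)N(C[C@@H]1CCCO1)S(=O)(=O)c1ccc(Cl)cc1` has not yet been measured. It differs from compound 2 in one place, on a saturated chain carbon bound to a sulfonamide nitrogen: oxolan-2-yl in place of 1,4-dioxan-2-yl on a saturated chain carbon bound to a sulfonamide nitrogen. For the measured compounds named here, only one measured step bears on this change, and it altered the same place: swapping 4,4-dimethyloxetan-2-yl for 1,4-dioxan-2-yl gave a 7.1-fold higher number from compound 1 to compound 2 (0.85 log units; beyond the scatter). That shows this place can move the number clearly, but it says nothing direct about oxolan-2-yl. Going by the values given here, with compound 2 at 117 mL/min/kg, the top of the numbers so far, a modest fall seems the likelier direction, although a change within the scatter remains possible. The expected change is a 2.3-fold lower number from compound 2 to compound 3 (0.37 log units; beyond the scatter). For compound 3 the estimated clearance is 50 mL/min/kg, with an expected range from 18 mL/min/kg to 130 mL/min/kg.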

Compound 3, clearance: 210 mL/min/kg
Compound 3: middle estimate off by 4.2-fold (0.62 log units), on the low side; the measured number lies above the stated range.
By their numbers in this assay, from the lowest: compound 1; then compounds 2 and 3 (each within the scatter of the next).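

In this assay, oxolan-2-yl in place of 1,4-dioxan-2-yl gives a 1.8-fold higher number from compound 2 to compound 3 (0.25 log units; within the scatter), so at this position the assay does not separate the five-membered ring with one hetero atom from the six-membered ring with two. Oxolan-2-yl in place of 4,4-dimethyloxetan-2-yl gives a 13-fold higher number from compound 1 to compound 3 (1.10 log units; beyond the scatter), so compound 1 now stands apart from two different rings, not just one. No measurement shown here explains these results.

As far as these compounds go, what remains open is whether the gap to compound 1 follows from its two methyl groups, its ring, or both together, since these all differ in a single step. A plain oxetan-2-yl or a 5,5-dimethyloxolan-2-yl at this place would help separate those possibilities.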